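A few compounds are considered here, and "the series" means these few. Any claim that something is new, unique, unknown or untested is made for them only; others in the source may bear on it.

Measured so far:
- compound 1, `CC(O)Cc1ccc2ccc(=O)oc2c1`, 99.4%
- compound 2, `O=c1ccc2ccc(/C=N/Nc3ccccc3)cc2o1`, 99.9%

In a functional assay for inhibition of serine protease 1 (Homo sapiens), tested at 1 mM (on this read-out higher numbers stand for a stronger effect at the one concentration tested and lower numbers for a weaker effect), compound 1 gives 99.4%, and in the same test compound 2 gives 99.9%. These two numbers lie within the usual scatter of each other, so on what is known compound 1 cannot be set apart from compound 2; both compounds give a read-out close to the top of the scale at the one concentration tested.

The next compound, compound 3, is `CO/N=C/c1ccc2ccc(=O)oc2c1`. Compared with compound 1 it carries a group of 4 heavy atoms (2 carbon, 1 nitrogen, 1 oxygen; no ring) in place of a group of 4 heavy atoms (3 carbon, 1 oxygen; no ring), on an aromatic carbon.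

For the measured compounds named here, no pair of measured compounds differs in only one place, so there is no measured step to lean on. Because compound 1 already gives 99.4% in this assay, a step of no size beyond the scatter is expected, in either direction. For compound 3 the inhibition in this assay is estimated at 95%, within a range from 80% to 100%, which is an expected step of a number 4.4 percentage points lower from compound 1 to compound 3 (within the scatter).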

Compound 3, a percentage reported as inhibition, at one concentration (the size of the read-out at that concentration, not a potency): 99.9%
The estimate for compound 3 lay 4.9 percentage points below the measured number; measured number inside the range.
By their numbers in this assay, from the lowest: compounds 1, 2 and 3 (each within the scatter of the next).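

In this assay, putting the new group in place of the 2-hydroxypropyl group on this aromatic carbon gives a number 0.5 percentage points higher from compound 1 to compound 3 (within the scatter). The new group has no ring, like the 2-hydroxypropyl group, but it carries a double bond outside aromatic rings and no hydrogen-bond donor, so at the one concentration tested, a read-out close to the top of the scale does not depend on the hydroxyl group of compound 1. No supporting data bear on why this swap leaves the read-out within the scatter.

With all three compounds close to the top of the scale, a single concentration cannot show whether their potencies differ. Going by these compounds, it also remains open whether an amine, a carboxylic acid or a longer chain on this aromatic carbon would give a read-out as high.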